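The source may hold more compounds than are shown below. What is called first, only, known or untested is meant among the compounds shown, and "the series" means these compounds.

In a functional assay on NALM-6 cells (Homo sapiens) for cytotoxicity, with a stated time of 72 h (on this read-out lower numbers stand for an effect already at smaller amounts and higher numbers for an effect only at larger amounts of compound), compound 1 `C=C[C@@](C)(/C=C/c1ccc(Nc2ccccc2)cc1)CCC=C(C)C` gives > 43400 nM, which is a limit of the assay and not a number. Compound 2 `C=C[C@@](C)(/C=C/c1ccc(Nc2ccc(OC)cc2)cc1)CCC=C(C)C` gives > 43400 nM, again a limit. Compound 3 `C=C[C@@](C)(/C=C/c1ccc(Nc2cc(F)c(F)c(F)c2)cc1)CCC=C(C)C` gives > 43400 nM, also a limit. All three therefore share one position: the limit of > 43400 nM in this assay, at which 3 of the 3 values shown sit. Compound 4 `C=C[C@@](C)(/C=C/c1ccc(Nc2c(F)cc(F)cc2F)cc1)CCC=C(C)C` differs from compound 3 in one place: 2,4,6-trifluorophenyl in place of 3,4,5-trifluorophenyl on a nitrogen on an aromatic ring. The measured steps that bear on this change are a step that the two limits leave unreadable from compound 1 to compound 3 and a step that the two limits leave unreadable from compound 2 to compound 3, and neither gives a size. Without a readable size or direction, no step beyond the scatter is expected in this assay. The expected change is a step that the limit leaves unreadable from compound 3 to compound 4. For compound 4 the estimate is 60000 nM, with an expected range of 30000 nM to 120000 nM.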

Compound 4, half-maximal effective concentration: > 43400 nM
Compound 4: only a limit was reported; the forecaster's own chance of this, stated with the estimate: 85%; the middle value lies beyond the limit too.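

No step can be read between compound 4 and compound 1, compound 2 or compound 3, since all four stand at one limit: the limit of > 43400 nM in this assay, at which 4 of the 4 values shown sit. The compounds shown leave open whether any group on that nitrogen gives a measurable effect in this assay.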